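Fluoro to chloro swap across two matched pairs

The source may hold more compounds than are shown below. What is called first, only, known or untested is meant among the compounds shown, and "the series" means these compounds.

The series holds four compounds on two cores. Compound 1 `O=C1/C(=C/c2ccc(F)cc2)CCC/C1=C\c1cccc([N+](=O)[O-])c1` and compound 2 `O=C1/C(=C/c2ccc(Cl)cc2)CCC/C1=C\c1cccc([N+](=O)[O-])c1` share one core; compound 3 `O=C1/C(=C/c2ccc(F)cc2)CCC/C1=C\c1ccc([N+](=O)[O-])cc1` and the unmeasured compound 4 `O=C1/C(=C/c2ccc(Cl)cc2)CCC/C1=C\c1ccc([N+](=O)[O-])cc1` share the other. How the core of compound 1 differs from the core of compound 3 is not broken down here; the two have the same atoms joined differently.

In a physicochemical assay for lipophilicity (a higher number here means a more lipophilic compound, a lower number a more polar compound), compound 1 gives 5.07 and compound 2 gives 5.58. The change between them is chloro in place of fluoro on an aromatic carbon and it makes the step of a number 0.51 log units higher from compound 1 to compound 2 (beyond the scatter). On the other core, compound 3 gives 5.09 in this assay, a number that lies within the scatter of the number for compound 1, so no order between those two is claimed.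

The change from compound 3 to compound 4 is chloro in place of fluoro on an aromatic carbon. Its place is described in the same words as the place of the change from compound 1 to compound 2, so it is taken as the same change, seen twice in all. Within the data shown here, only one measured instance exists, so the expectation rests on that single step and carries its uncertainty.

Compound 4 is expected to reach 5.6 in this assay, with a range from 5.35 to 5.85. Among the measured compounds shown here, the expected step of a number 0.51 log units higher from compound 3 to compound 4 (beyond the scatter) is set to mirror the earlier step because a number 0.51 log units higher from compound 1 to compound 2 (beyond the scatter) is the only measured instance of this change.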

Compound 4, partition coefficient: 5.6
For compound 4 middle estimate and measured number coincide at the digits printed; measured number inside the range.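

In this assay the new step is a number 0.51 log units higher from compound 3 to compound 4 (beyond the scatter) and the earlier step is a number 0.51 log units higher from compound 1 to compound 2 (beyond the scatter) so the change from 4-fluorophenyl to 4-chlorophenyl has the same size on both cores at the digits printed, and in this series it carried from the core of compound 1 to the core of compound 3 without any visible loss or gain. This rests on two instances of one swap in one read-out, on two cores that have the same atoms joined differently, so it shows agreement for this pair of cores and does not show that the step would hold on a core further removed from these, or for any other swap at this place. No measurement is available that speaks to why the two steps agree, and the notes offer no account of it.

The compounds shown carry only fluoro and chloro at this place and only a nitro group on the other aromatic ring. From the compounds shown here alone, whether the step keeps its size when bromo, methoxy or an amine enters at this place, or when a carboxylic acid stands in place of the nitro group, remains open.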